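A Fluorophenyl Swap on a Weak Growth Inhibitor

The compounds below may be only part of what the source reports. "The series", "measured", "known", "first", "only" and "open" are said of these compounds alone.

In a functional assay on DU-145 cells (Homo sapiens) for inhibition, read by trypan blue exclusion, with a stated time of 96 h (a lower number here means a stronger inhibitor of growth, a higher number a weaker inhibitor of growth), compound 1 `O=C(O)c1ccc(C(=O)/C(=C\c2ccc([N+](=O)[O-])c(O)c2)SCc2ccc(Br)cc2)cc1` gives 10000 nM, and compound 2 `O=C(/C(=C\c1ccc([N+](=O)[O-])c(O)c1)SCc1ccc(Br)cc1)c1ccc(Br)cc1` gives 10000 nM. Between them the data show no change at the digits printed from compound 1 to compound 2 (within the scatter), so compound 1 stands level with compound 2. Compound 3 `O=C(/C(=C\c1ccc([N+](=O)[O-])c(O)c1)SCc1ccc(Br)cc1)C1CCNC1` gives > 100000 nM, which is a limit of the assay. The change on the carbonyl carbon gives an at least 10-fold higher number from compound 1 to compound 3 (1.00 log units; beyond the scatter) and an at least 10-fold higher number from compound 2 to compound 3 (1.00 log units; beyond the scatter).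

Compound 4 `O=C(O)c1ccc(C(=O)/C(=C\c2ccccc2F)SCc2ccc(Br)cc2)cc1` differs from compound 1 as follows: 2-fluorophenyl in place of 3-hydroxy-4-nitrophenyl on a double-bonded chain carbon bound to a double-bonded chain carbon. Among the measured compounds shown here, none of the measured steps touches this place, so they offer no size or direction for it, and only a loose expectation remains. The estimated change is a 1.5-fold higher number from compound 1 to compound 4 (0.18 log units; within the scatter), with no step beyond the scatter firmly expected in this assay. Compound 4 is estimated at 15000 nM, with a range of 4000 nM to 60000 nM.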

Compound 4, concentration for 50% growth inhibition: 10000 nM
Compound 4: the middle estimate sits 1.5-fold (0.18 log units) above what was measured; the measured number falls inside the stated range.
By their numbers in this assay, from the lowest: compounds 1, 2 and 4 (each within the scatter of the next). At a limit, above all of these: compound 3.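

In this assay, among the compounds shown here, the swap to 2-fluorophenyl shows no change at the digits printed from compound 1 to compound 4 (within the scatter), the first reading at this place, on a double-bonded chain carbon bound to a double-bonded chain carbon. The 3-hydroxy-4-nitrophenyl group, with its hydrogen-bond donor and acceptors, can thus give way to a group with neither and leave the number unmoved. Nothing shown bears on why this step is flat. Still open, from the compounds shown here alone, is whether an amine on this ring, or a longer chain in its place, would move the number at all.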